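Chain homologation on the amide side of the series

The source may report more compounds than this note shows. Statements on the series, on what has been measured and on what is new or still open speak of the compounds shown alone.

Compound 3 `COc1cc(C(=O)NS(=O)(=O)c2ccccc2C)ccc1Cc1cn(C)c2ccc(C(=O)NCCC(C)C(F)(F)F)cc12` stands highest of the three numbers in a physicochemical assay for lipophilicity (on this read-out higher numbers stand for higher lipophilicity and lower numbers for lower lipophilicity), at 6.3. Compound 2 `COc1cc(C(=O)NS(=O)(=O)c2ccccc2C)ccc1Cc1cn(C)c2ccc(C(=O)NCC(C)C(F)(F)F)cc12` gives 5.89 in this assay, and compound 1 `CCC(CNC(=O)c1ccc2c(c1)c(Cc1ccc(C(=O)O)cc1OC)cn2C)CC(F)(F)F` gives 5.53. Within the data shown here, the one step that bears on the change is a number 0.41 log units higher from compound 2 to compound 3 (beyond the scatter), a gain beyond the scatter for one added carbon. Compound 4 `CCC(CNC(=O)c1ccc2c(c1)c(Cc1ccc(C(=O)NS(=O)(=O)c3ccccc3C)cc1OC)cn2C)CC(F)(F)F` carries the same change in kind: 1-(2,2,2-trifluoroethyl)propyl in place of 2-(trifluoromethyl)propyl on a saturated chain carbon bound to an amide-type nitrogen. That step again adds one carbon on the chain and nothing polar, so a modest rise in this assay of about the same size is expected, not a fall. The expected step is a number 0.35 log units higher from compound 3 to compound 4 (beyond the scatter). For compound 4 the estimate in this assay is 6.65, within 6.25 to 7.05.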

Compound 4, partition coefficient: 6.45
Compound 4: the middle estimate sits 0.20 log units above what was measured; low and high end bracket the measured number.
By their numbers in this assay, from the lowest: compound 1; then compound 2; then compounds 3 and 4 (each within the scatter of the next).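

In this assay, the branched 1-(2,2,2-trifluoroethyl)propyl gives a number 0.15 log units higher from compound 3 to compound 4 (within the scatter) and so does not clearly extend the earlier rise of a number 0.41 log units higher from compound 2 to compound 3 (beyond the scatter) on this chain. Against the shorter 1-(trifluoromethyl)ethyl, the read is a number 0.56 log units higher from compound 2 to compound 4 (beyond the scatter) and the chain change still counts. On the carbonyl carbon, ((2-methylphenyl)sulfonyl)amino in place of hydroxy gives a number 0.92 log units higher from compound 1 to compound 4 (beyond the scatter) with the chain held constant, but no available evidence accounts for any of these steps.

Open, as far as these compounds go, is whether a longer chain would move the number beyond the scatter. Also open, from the compounds shown here alone, is how an amine or a nitrile at the chain end would read.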